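From cyclohexyl to 4-chlorophenyl on an amide-type nitrogen

The compounds below may be only part of what the source reports. "The series", "measured", "known", "first", "only" and "open" are said of these compounds alone.

Compound 1 `O=C(Nc1ccc(Nc2nccc(NC3CCCCC3)n2)cc1)Nc1ccc(Cl)c(C(F)(F)F)c1` gives 10800 nM
Compound 2 `O=C(Nc1ccc(Nc2nccc(NC3CCCC3)n2)cc1)NC1CCCCC1` gives 19200 nM

Both numbers come from a functional assay on MCF7 cells (Homo sapiens) for antiproliferative activity, read by MTT assay, with a stated time of 72 h (on this read-out higher numbers stand for weaker inhibition and lower numbers for stronger inhibition), and show how well each compound holds back cell growth. Compound 2 stands level with compound 1, as their two values lie within the usual scatter of each other. These two compounds also differ in more than one place, so this pair cannot show the effect of any single change.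

Compound 3 `O=C(Nc1ccc(Cl)cc1)Nc1ccc(Nc2nccc(NC3CCCC3)n2)cc1` has not yet been measured. It is compound 2 with 4-chlorophenyl in place of cyclohexyl on an amide-type nitrogen. For the measured compounds named here, no measured pair shows this change alone. The nearest hint is compound 1, which also has a chlorine-bearing aromatic ring on an amide-type nitrogen and gives 10800 nM in this assay while differing from compound 3 elsewhere. The expected step (a 1.7-fold lower number from compound 2 to compound 3 (0.24 log units; within the scatter)) is therefore a modest drop in the number that stays within the scatter. For compound 3 the estimate is 11000 nM as the expected value, with an expected range from 4500 nM to 25000 nM for the measurement.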

Compound 3, half-maximal inhibitory concentration: 22000 nM
Compound 3: middle estimate off by 2.0-fold (0.30 log units), on the low side; low and high end bracket the measured number.
By their numbers in this assay, from the lowest: compounds 1, 2 and 3 (each within the scatter of the next, the first and the last beyond it).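

In this assay, for the compounds shown here, the step gives a 1.1-fold higher number from compound 2 to compound 3 (0.06 log units; within the scatter) when 4-chlorophenyl replaces cyclohexyl on the amide-type nitrogen, and this is the first pair here in which only one group differs. Compound 2 and compound 3 therefore stand level, so this read-out does not separate a six-membered non-aromatic ring of carbon only from a six-membered aromatic ring bearing a chlorine at this position, even though the two groups differ in both ring type and the added chlorine. The data at hand offer no explanation for why these two groups read alike.

The compounds shown leave open whether a plain phenyl, a phenyl ring carrying a carboxylic acid or an amine, or an open chain such as ethyl on this nitrogen would stand level with these two groups or move the number beyond the scatter. Also open, as far as these compounds go, is whether this same swap would still read level if the shared core carried a different group elsewhere.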